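Methylthio replaces iodothio on the shared purine riboside core

The source may report more compounds than this note shows. Statements on the series, on what has been measured and on what is new or still open speak of the compounds shown alone.

Compound 3 `Nc1nc(SI)c2ncn([C@@H]3O[C@H](CO)[C@@H](O)[C@H]3O)c2n1` gives 81300 nM in an assay on isolated protein for binding affinity to Equilibrative nucleoside transporter 1 (Homo sapiens) (a higher number here means a weaker inhibitor, a lower number a stronger inhibitor), the highest of the three numbers measured. Compound 1 `Nc1nc(SCc2cccc(Br)c2)c2ncn([C@@H]3O[C@H](CO)[C@@H](O)[C@H]3O)c2n1` gives 2880 nM in this assay, and compound 2 `Nc1nc(SCc2ccc(Br)cc2)c2ncn([C@@H]3O[C@H](CO)[C@@H](O)[C@H]3O)c2n1` gives 813 nM. The two measured steps that reach compound 3 are both large: a 28-fold higher number from compound 1 to compound 3 (1.45 log units; beyond the scatter) and a 100-fold higher number from compound 2 to compound 3 (2.00 log units; beyond the scatter), each a move from a bromobenzyl group on the sulfur to iodo. Compound 4 `CSc1nc(N)nc2c1ncn2[C@@H]1O[C@H](CO)[C@@H](O)[C@H]1O` carries methyl in place of iodo on a sulfur. For the measured compounds named here, no measured step exchanges iodo for methyl on this sulfur, so the size of the change is not anchored by any pair; what is known is only that a bromobenzyl on the sulfur gives far lower numbers than iodo. A methyl is as small as the iodo it replaces and lacks any ring, so in this assay compound 4 is expected to show a 4.1-fold lower number from compound 3 to compound 4 (0.61 log units; beyond the scatter), a moderate move toward lower numbers with wide uncertainty. Compound 4 is estimated at 20000 nM, with a range of 5000 nM to 80000 nM.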

Compound 4, half-maximal inhibitory concentration: 204000 nM
For compound 4 the middle estimate is 10-fold (1.01 log units) below the measured one, and the stated range ends below it.
By their numbers in this assay, from the lowest: compound 2; then compound 1; then compound 3; then compound 4.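

In this assay methyl gives the highest number of the groups shown on this sulfur, and the exchange for iodo gives a 2.5-fold higher number from compound 3 to compound 4 (0.40 log units; beyond the scatter) so that two groups of a single heavy atom are told apart by a step beyond the scatter. With methyl as the reference, the compounds now show what each bromophenyl on the saturated chain carbon bound to the sulfur is worth: removing the 4-bromophenyl corresponds to a 250-fold higher number from compound 2 to compound 4 (2.40 log units; beyond the scatter) and removing the 3-bromophenyl to a 71-fold higher number from compound 1 to compound 4 (1.85 log units; beyond the scatter) and both steps are large. The compounds shown leave open where a plain benzyl without bromine or a longer chain such as propyl on this sulfur would fall between compound 2 and compound 4. No available evidence bears on the reason for these steps.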